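The source may report more compounds than this note shows. Statements on the series, on what has been measured and on what is new or still open speak of the compounds shown alone.

Working notes on the series. In an in vivo ADME assay on the whole organism for pharmacokinetics, at a dose of 2.5 mg/kg by the oral route (a lower number here means that the compound disappears faster, a higher number that the compound lasts longer), compound 3 `Cn1nc(-c2ccc(C(N)=O)cc2)s/c1=N\C1CCCCC1O` stands at the lowest of the two single numbers, giving 0.31 h. Its nearest neighbour on that scale is compound 2 `Cn1nc(-c2ccc(C(=O)NC(C)(C)CO)cc2)s/c1=N\C1CCCC(O)C1`, which in this assay gives 0.46 h, a gap that lies within the usual scatter. Compound 1 `Cn1nc(-c2ccc(S(C)(=O)=O)cc2)s/c1=N\C1CCCC(O)C1` has only repeated entries rather than one number, (the several entries of compound 1 in this assay, 2 h; 2.5 h (2 entries)), and so sits apart from the comparison; in this assay compound 1 gives 2 h; 2.5 h (2 entries). Compound 4 `Cn1nc(-c2ccc(C(N)=O)cc2)s/c1=N\C1CCC(O)CC1` is not yet measured in this assay; it differs from compound 3 by 4-hydroxycyclohexyl in place of 2-hydroxycyclohexyl on a double-bonded nitrogen. Among the compounds with values here, no measured pair shows this change, so the expected step from compound 3 to compound 4 is a 1.1-fold higher number from compound 3 to compound 4 (0.05 log units; within the scatter), nothing beyond the scatter in either direction. Compound 4 is therefore estimated at 0.35 h, between 0.15 h and 0.8 h.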

Compound 4, half-life: 0.27 h
For compound 4 the middle estimate is 1.3-fold (0.11 log units) above the measured one; the range from low to high includes it.
By their numbers in this assay, from the lowest: compounds 4, 3 and 2 (each within the scatter of the next).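

Within the data shown here, the change to 4-hydroxycyclohexyl in place of 2-hydroxycyclohexyl on a double-bonded nitrogen gives the first single-place step in this assay, namely a 1.1-fold lower number from compound 3 to compound 4 (0.06 log units; within the scatter). Half-life therefore does not tell compound 3 and compound 4 apart, and these two hydroxycyclohexyl groups are equivalent at this position within the scatter. Nothing available bears on the reason for this result. Open, going by these compounds, is whether an amine or a carboxylic acid in place of the hydroxyl on the cyclohexyl ring would give a half-life beyond the scatter of these two compounds. Also open, on these data alone, is whether the same change reads alike with a different group on the shared core.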